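A few compounds are considered here, and "the series" means these few. Any claim that something is new, unique, unknown or untested is made for them only; others in the source may bear on it.

Measured in a functional assay on HaCaT cells (Homo sapiens) for antiproliferative activity, read by sulforhodamine B assay, with a stated time of 3 days (a higher number here means a weaker inhibitor, a lower number a stronger inhibitor), so far:
- compound 1 (`COC(=O)c1cc(CCc2cccc(OC)c2OC)ccc1O`) gives 33000 nM
- compound 2 (`COC(=O)c1cc(CCc2cc(OC)ccc2O)ccc1O`) gives 1100 nM
- compound 3 (`COC(=O)c1cc(CCc2cc(O)ccc2O)ccc1O`) gives 21000 nM

Going by the values given here, compound 2 holds the lowest number of the three, 1100 nM in the series so far. Compound 4 (`COC(=O)c1cc(CCc2cc(OC)ccc2N(C)C)ccc1O`) carries dimethylamino in place of hydroxy on an aromatic carbon, para to a methoxy group. The change counts as dimethylamino in place of hydroxy on an aromatic carbon in full. Among the compounds with values here, no measured step touches this hydroxy. The nearest evidence, at a different place, is a 19-fold higher number from compound 2 to compound 3 (1.28 log units; beyond the scatter) and it shows how far one small change moved the number here. In this assay a higher number is therefore expected, though a smaller step than that one. The expected step is a 5.5-fold higher number from compound 2 to compound 4 (0.74 log units; beyond the scatter) as estimated. For compound 4 the estimated value is 6000 nM and 1300 nM to 28000 nM is the expected range.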

Compound 4, half-maximal inhibitory concentration: 650 nM
Estimate against measurement, compound 4: 9.2-fold (0.97 log units) above; measured number below the stated range.
By their numbers in this assay, from the lowest: compounds 4 and 2 (each within the scatter of the next); then compounds 3 and 1 (each within the scatter of the next).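

In this assay the hydroxy on this aromatic carbon gives way to dimethylamino with a 1.7-fold lower number from compound 2 to compound 4 (0.23 log units; within the scatter) and no change beyond the scatter, so this place accepts a group of 3 heavy atoms with 0 hydrogen-bond donors. The earlier compounds shown here showed a large step at the methoxy group, a 19-fold higher number from compound 2 to compound 3 (1.28 log units; beyond the scatter) and none at this carbon. No measurement on hand explains why the number holds here.

Still open, going by these compounds, is how a primary amine or a methylamino group would read at this carbon. On these data alone, whether dimethylamino holds its number with a group other than methoxy in that ring is also open.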